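A few compounds are considered here, and "the series" means these few. Any claim that something is new, unique, unknown or untested is made for them only; others in the source may bear on it.

Measured compounds and their values:
Compound 1 `Cc1ccc(-c2cs/c(=N/NC(=O)CSc3nnnn3-c3ccccc3)n2-c2ccccc2)cc1`: 55.1%
Compound 2 `Cc1ccc(-c2cs/c(=N/NC(=O)CSc3nncn3C)n2-c2ccccc2)cc1`: 72%
Compound 3 `Cc1ccc(-c2cs/c(=N/NC(=O)CSc3nnnn3C)n2-c2ccccc2)cc1`: 68.8%

All three were tested in a functional assay on C6 cells (Rattus norvegicus) for cytotoxicity, read by MTT assay, with a stated time of 24 h, tested at 12 ug/mL; a higher number here means a weaker effect of the compound at the concentration tested, a lower number a stronger effect. Compound 2 gives the highest of the three numbers, which here means the weakest effect. Among the measured compounds shown here, its nearest neighbour is compound 3, with a number 3.2 percentage points lower from compound 2 to compound 3 (within the scatter), a gap within the scatter; the only steps beyond the scatter are a number 16.9 percentage points higher from compound 1 to compound 2 (beyond the scatter) and a number 13.7 percentage points higher from compound 1 to compound 3 (beyond the scatter), both of which concern the group on the sulfur or on the aromatic nitrogen, not the ring at the other end of the shared core.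

Compound 4 `Cn1cnnc1SCC(=O)N/N=c1/scc(-c2ccc(C#N)cc2)n1-c1ccccc1` is not yet measured. It differs from compound 2 in one place: cyano in place of methyl on an aromatic carbon. For the measured compounds named here, none of the measured steps touches this position; every change so far was made at the sulfur-bound group or the aromatic nitrogen, so the data give no direct guide to what a cyano in place of a methyl on the six-membered carbon ring does in this assay. Going by the values given here, with no comparable step available, the expectation is that the number for compound 4 stays close to that of compound 2, giving an estimated step of a number 2 percentage points lower from compound 2 to compound 4 (within the scatter), not beyond the scatter. Compound 4 is therefore estimated at 70%, within a range from 50% to 90%.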

Compound 4, a percentage reported as activity, at one concentration (the size of the read-out at that concentration, not a potency): 62.6%
For compound 4 the middle estimate is 7.4 percentage points above the measured one; the range from low to high includes it.
By their numbers in this assay, from the lowest: compounds 1, 4, 3 and 2 (each within the scatter of the next, the first and the last beyond it).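

The change from 4-methylphenyl to 4-cyanophenyl is the first one shown at this end of the shared core, and in this assay it gives a number 9.4 percentage points lower from compound 2 to compound 4 (within the scatter). In this one pair, then, putting cyano in place of methyl on an aromatic carbon, para to a large group, cannot be told apart from leaving the methyl in place, even though cyano brings one more heavy atom and a hydrogen-bond acceptor. Nothing measured here bears on why this swap behaves as it does, and no property of either group can be drawn from these values.

Going by these compounds, only one replacement at this position appears, so it remains open whether an amine, a carboxylic acid or a longer chain in place of the methyl would give a step beyond the scatter. It is also open whether the swap from methyl to cyano would read the same with 1-phenyl-1H-tetrazol-5-yl on the sulfur, the group carried by compound 1, since the pair shown has only the 4-methyl-4H-1,2,4-triazol-3-yl group there.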